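The compounds below may be only part of what the source reports. "The series", "measured", "known", "first", "only" and "open" are said of these compounds alone.

Of the compounds shown here, three have so far been tested in a functional assay on the whole organism for antagonist activity, with Rattus norvegicus as the target; on this read-out higher numbers stand for an effect only at larger amounts of compound and lower numbers for an effect already at smaller amounts. Compound 1 `Clc1cccc2c1CC2CCN1CCN(c2cccc3c2OCCO3)CC1` gives 1.25 mg/kg in this assay, the highest of the three numbers. Compound 2 `c1ccc2c(c1)CC2CN1CCN(c2cccc3c2OCCCO3)CC1` gives 0.63 mg/kg, and compound 3 `Clc1cccc2c1CC2CN1CCN(c2cccc3c2OCCO3)CC1` gives 0.63 mg/kg; both of these lie within the usual scatter of the number for compound 1, so no order among the three compounds can be read from what is known. Going by the values given here, no pair of measured compounds differs in a single place, so no measured step is available to guide the next change.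

Compound 4 `c1ccc2c(c1)CCC2CCN1CCN(c2cccc3c2OCCO3)CC1` has not yet been measured. It differs from compound 1 as follows: a group of 9 heavy atoms (9 carbon; one five-membered non-aromatic ring of carbon only, one six-membered aromatic ring of carbon only) in place of a group of 9 heavy atoms (8 carbon, 1 chlorine; one four-membered non-aromatic ring of carbon only, one six-membered aromatic ring of carbon only), on a saturated chain carbon, two bonds along the chain from an amine nitrogen in a ring. Among the compounds with values here, with no measured step of this kind at hand, the expectation for compound 4 can rest only on the narrow spread seen among compound 1, compound 2 and compound 3, and the step of a 1.3-fold lower number from compound 1 to compound 4 (0.10 log units; within the scatter) is expected to be small, in either direction, and not beyond the scatter. Compound 4 is therefore estimated to give 1 mg/kg in this assay, within a range from 0.4 mg/kg to 2.5 mg/kg.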

Compound 4, minimum effective dose: 0.63 mg/kg
For compound 4 the middle estimate is 1.6-fold (0.20 log units) above the measured one, within the range that was stated.
By their numbers in this assay, from the lowest: compounds 2, 3, 4 and 1 (each within the scatter of the next).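

Going by these compounds alone, the first measured step at this place in this assay is a 2.0-fold lower number from compound 1 to compound 4 (0.30 log units; within the scatter), with 2,3-dihydro-1H-inden-1-yl taking the place of the chlorine-bearing group with the four-membered ring, on a saturated chain carbon, two bonds along the chain from an amine nitrogen in a ring. At this place, then, one group of 9 heavy atoms can stand in for the other without the number leaving the scatter, even though the ring size and the chlorine differ together. Nothing measured on any property of these groups bears on this result.

This single step cannot separate the ring size from the chlorine. Going by these compounds, whether a group carrying a hydroxyl or an amine, or a longer chain, would give a step beyond the scatter at this place remains open.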